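Series notes: compound 3 to compound 4, hydroxy for methyl

The source may report more compounds than this note shows. Statements on the series, on what has been measured and on what is new or still open speak of the compounds shown alone.

Compound 1 `CC1=CC[C@@H]([C@@](C)(O)CCCC(C)(C)NC=S)CC1` is the parent of the set. In a functional assay on MCF7 cells (Homo sapiens) for cytotoxicity, read by sulforhodamine B assay (a higher number here means that more compound is tolerated, a lower number that less compound is tolerated), compound 1 gives > 100000 nM, which is a limit of the assay and not a number. Compound 2 `CC1=CC[C@@H]([C@@](C)(O)CCCC(C)(C)NC(=S)NN)CC1` carries aminoamino in place of hydrogen on the thiocarbonyl carbon. In this assay compound 2 gives > 100000 nM, again only a limit. Compound 3 `CC1=CC[C@@H]([C@@](C)(O)CCCC(C)(C)NC(=S)N/N=C\c2ccc(C)cc2)CC1` adds the larger group on the amide-type nitrogen. In this assay compound 3 gives > 100000 nM, once more a limit. Both steps, a step that the two limits leave unreadable from compound 1 to compound 2 and a step that the two limits leave unreadable from compound 2 to compound 3, are therefore unreadable in size, because every value sits at the limit of > 100000 nM in this assay, at which 3 of the 3 values shown sit.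

Compound 3 thus stands only at a limit, with no number to rank it against the two other compounds. Compound 4 `CC1=CC[C@@H]([C@@](C)(O)CCCC(C)(C)NC(=S)N/N=C\c2ccc(O)cc2)CC1` differs from compound 3 by hydroxy in place of methyl on an aromatic carbon. Among the compounds with values here, no measured step bears on this change, and the two steps give no readable size at all. There is nothing in the data that points to a step beyond the scatter in either direction. The expected step that the limit leaves unreadable from compound 3 to compound 4 is therefore estimated as essentially none. Compound 4 in this assay is expected near 120000 nM, with a range from 50000 nM to 300000 nM, most likely reported as a limit once more.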

Compound 4, concentration lethal to 50% of the cells: 56400 nM
Compound 4: the middle estimate sits 2.1-fold (0.33 log units) above what was measured; the range from low to high includes it.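

Within the data shown here, with 4-hydroxyphenyl in place of 4-methylphenyl, the series gives its only number so far in this assay, and the change reads as an at least 1.7-fold lower number from compound 3 to compound 4 (0.24 log units; that floor lies within the scatter). The larger replacement on the amide-type nitrogen gives the same reading, an at least 1.7-fold lower number from compound 2 to compound 4 (0.24 log units; that floor lies within the scatter). Both readings are floors and not sizes, and the steps among the three earlier compounds cannot be read, so the result shows only that a change at this place on the aromatic ring can bring a value into the measured range, while any true step beyond the scatter remains unproven: the limit of > 100000 nM in this assay, at which 3 of the 4 values shown sit.

As far as these compounds go, it remains open whether methoxy, an amine or a carboxylic acid at the same place on the aromatic ring would also give a number in this assay, and how those values would stand against that of compound 4. Also open, from the compounds shown here alone, is whether a change elsewhere, such as a longer chain in place of the one that carries the thiocarbonyl group on the shared core, would move the value of compound 4 by more than the scatter.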